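The source may hold more compounds than are shown below. What is called first, only, known or untested is meant among the compounds shown, and "the series" means these compounds.

Working notes on the series. Compound 1 `O=c1cc(-c2ccccc2)oc2cc(O)c(OCc3ccccc3)c(O)c12` is the reference; in an assay on HepG2 cells with cyclic AMP-responsive element-binding protein 1 (Homo sapiens) as the target, read by a luciferase reporter, with a stated time of 4 h (on this read-out lower numbers stand for an effect already at smaller amounts and higher numbers for an effect only at larger amounts of compound), compound 1 gives 4300 nM. Compound 2 `CCCOc1c(O)cc2oc(-c3ccccc3)cc(=O)c2c1O` is the closest analogue; in this assay compound 2 gives 1700 nM. Within the data shown here, the single measured step, a 2.5-fold lower number from compound 1 to compound 2 (0.40 log units; beyond the scatter), runs downward. Among the measured compounds shown here, on the two numbers in hand, compound 2 therefore stands at the lower one, with compound 1 as its only neighbour.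

Compound 3 `CC(=O)Oc1c(O)cc2oc(-c3ccccc3)cc(=O)c2c1O` is the next case: it differs from compound 2 by acetyl in place of propyl on an oxygen on an aromatic ring. The measured step bears on this only loosely: it exchanged one group on the same oxygen for another, but both were saturated carbon chains, whereas here propyl is replaced by acetyl. For the measured compounds named here, no measured step tells the direction of that exchange, so the expectation is a number close to that of compound 2 in this assay, with a wide margin. Compound 3 is expected to give 2500 nM, an expected step of a 1.5-fold higher number from compound 2 to compound 3 (0.17 log units; within the scatter), within a range from 800 nM to 8000 nM.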

Compound 3, concentration for half-maximal activity: 13900 nM
For compound 3 the middle estimate is 5.6-fold (0.75 log units) below the measured one; measured number above the stated range.
By their numbers in this assay, from the lowest: compound 2; then compound 1; then compound 3.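

The oxygen on the aromatic ring tolerates the two saturated groups far better than the ester-forming acetyl: in this assay, acetyl in place of propyl gives an 8.2-fold higher number from compound 2 to compound 3 (0.91 log units; beyond the scatter), a larger step than a 2.5-fold lower number from compound 1 to compound 2 (0.40 log units; beyond the scatter) between the two earlier groups. Acetyl in place of benzyl points the same way, with a 3.2-fold higher number from compound 1 to compound 3 (0.51 log units; beyond the scatter), so compound 3 has the highest number of the three. Propyl and acetyl have the same heavy-atom count, so this rise comes without a change in that count, while acetyl adds a hydrogen-bond acceptor and a double bond outside aromatic rings. Nothing at hand accounts for the rise.

As far as these compounds go, whether the carbonyl of acetyl alone carries this shift stays open. A butyl chain or a carbamate on the same oxygen would bear on that.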